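Replacing a Chlorophenyl Group with Pyridin-2-yl

The source may report more compounds than this note shows. Statements on the series, on what has been measured and on what is new or still open speak of the compounds shown alone.

Measured so far:
Compound 1 `Cc1ccc(-c2cc(-c3ccoc3)cc(-c3ccc(Cl)s3)n2)o1`: 13.2%
Compound 2 `Cc1ccccc1-c1cc(-c2ccoc2)cc(-c2ccc(Cl)s2)n1`: 4.6%
Compound 3 `Clc1ccc(-c2cc(-c3ccoc3)cc(-c3ccc(Cl)s3)n2)cc1`: 2.3%

In an assay on isolated protein for inhibition of DNA topoisomerase 1 (Homo sapiens), with a stated time of 30 min, tested at 100 uM (on this read-out higher numbers stand for more inhibition at the one concentration tested (going by the name of the read-out) and lower numbers for less inhibition), compound 3 sits at the low end of the three numbers; the two gaps that separate it from the others are a number 2.3 percentage points lower from compound 2 to compound 3 (within the scatter) and a number 10.9 percentage points lower from compound 1 to compound 3 (beyond the scatter). Compound 4 `Clc1ccc(-c2cc(-c3ccoc3)cc(-c3ccccn3)n2)s1` differs from compound 3 in one place: pyridin-2-yl in place of 4-chlorophenyl on an aromatic carbon. All three measured steps exchange the group at this same aromatic carbon, and they were small: a number 8.6 percentage points lower from compound 1 to compound 2 (within the scatter), a number 10.9 percentage points lower from compound 1 to compound 3 (beyond the scatter), a number 2.3 percentage points lower from compound 2 to compound 3 (within the scatter). None of them introduces pyridin-2-yl, so nothing specific is known about it, but the numbers all stay low. A step of a number 3.7 percentage points higher from compound 3 to compound 4 (within the scatter) is therefore expected, with no change beyond the scatter. For compound 4 the estimate is 6%, between -4% and 18%.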

Compound 4, a percentage reported as inhibition, at one concentration (the size of the read-out at that concentration, not a potency): 3.1%
The estimate for compound 4 lay 2.9 percentage points above the measured number; measured number inside the range.
By their numbers in this assay, from the lowest: compounds 3, 4, 2 and 1 (each within the scatter of the next, the first and the last beyond it).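

Pyridin-2-yl places a hydrogen-bond acceptor on this aromatic carbon, yet the measurements show a number 0.8 percentage points higher from compound 3 to compound 4 (within the scatter) and a number 1.5 percentage points lower from compound 2 to compound 4 (within the scatter), so this exchange cannot be told apart from either phenyl group. Against the 5-methylfuran-2-yl group, the measurements show a number 10.1 percentage points lower from compound 1 to compound 4 (beyond the scatter) and thus a modest separation, although compound 2 remains within the scatter of compound 1. No evidence here accounts for these results.

Still open, as far as these compounds go, is whether a non-aromatic group at this carbon, such as an aminomethyl group or a carboxylic acid, would give a clearly higher number.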